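Removing the Bromine from Compound 2: What to Expect

The source may report more compounds than this note shows. Statements on the series, on what has been measured and on what is new or still open speak of the compounds shown alone.

Measured so far:
compound 1, `COc1ccc(/C=C/C(=O)c2ccc[nH]2)c(OC)c1`: in an assay for inhibition of cytochrome P450 1A1 (Homo sapiens), read by fluorescence, using microsomes, with a stated time of 10 min (a lower number here means a stronger inhibitor, a higher number a weaker inhibitor), compound 1 gives 11800 nM
compound 2, `COc1ccc(/C=C/C(=O)c2ccc[nH]2)cc1Br`: in this assay compound 2 gives > 20000 nM

Both compounds share a core and differ only in the groups on the six-membered ring of carbon only. Compound 1 gives an actual number in this assay, and a weak one. The value of compound 2 is a limit of the assay, not a number, so compound 2 stands at the weak edge of what this assay can report. (the limit of > 20000 nM in this assay, at which 1 of the 2 values shown sits). Within the data shown here, since the two compounds differ in more than one place, no single step between them can be tallied.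

Compound 3, `COc1ccc(/C=C/C(=O)c2ccc[nH]2)cc1`, has not been measured. It differs from compound 2 in one place: hydrogen in place of bromo on an aromatic carbon. With compound 2 known only as a limit, the step to compound 3 cannot be read from data; it is estimated that going from compound 2 to compound 3 gives an at least 1.3-fold lower number from compound 2 to compound 3 (0.12 log units; that floor lies within the scatter), a change toward stronger inhibition but still within weak territory. Compound 3 is therefore expected to give about 15000 nM in this assay, with a likely range from 4000 nM to 60000 nM.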

Compound 3, half-maximal inhibitory concentration: > 20000 nM
Compound 3 was reported as a limit; the forecaster's own chance of this, stated with the estimate: 45%; middle value at least 1.3-fold (0.12 log units) from the limit.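

Removing the bromo group does not lift compound 3 out of the weak edge of the assay, and this value is again a limit: in this assay compound 3 gives > 20000 nM. The step between compound 2 and compound 3 cannot be read, so the effect of swapping bromo for hydrogen on this aromatic carbon, ortho to a methoxy group, has no size here, because both compounds sit at the same edge of the assay: the limit of > 20000 nM in this assay, at which 2 of the 3 values shown sit. Going by these compounds, compound 3 does open one new comparison, the swap of a methoxy group for hydrogen, which gives an at least 1.6-fold higher number from compound 1 to compound 3 (0.22 log units; that floor lies within the scatter); this shows no move toward stronger inhibition when that methoxy group is lost, although the true size of the step remains unknown.

On these data alone, with no actual number for compound 2 or compound 3, it remains open whether bromo and hydrogen differ at all at this position. As far as these compounds go, it also remains open whether another group on this carbon, such as an amine or a carboxylic acid, would give a real number in this assay rather than a limit.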